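Swapping furan for chlorophenyl on a spiro scaffold

This account rests on a few compounds, and the source may have more. Where it says the series, first, only, none or still open, it means among the compounds named here.

Of the compounds shown here, two of a shared core have been tested in a functional assay on the whole organism (strain Wister albino) for inhibition, with Rattus norvegicus as the target, read by paw edema, with stated times of 1 h and 2 h, at a dose of 50 mg/kg by the intraperitoneal route; a lower number here means less inhibition, a higher number more inhibition at the dose given (going by the name of the read-out). Compound 1 `CN1C[C@@H](c2ccccc2)[C@@]2(Cc3ccccc3C2=O)[C@@]12C(=O)Nc1ccccc12` gives 40%. Compound 2 `CN1C(=O)[C@@]2(c3ccccc31)N(C)C[C@@H](c1ccco1)[C@@]21Cc2ccccc2C1=O` gives 33.1%, a number that lies within the usual scatter of the result for compound 1, so the two cannot be told apart. Compound 3 `CN1C(=O)[C@@]2(c3ccccc31)N(C)C[C@@H](c1ccc(Cl)cc1)[C@@]21Cc2ccccc2C1=O` is not yet measured; it differs from compound 2 by 4-chlorophenyl in place of furan-2-yl on a saturated ring carbon. Among the compounds with values here, no measured pair shows what this change does, so the step is expected to stay within the scatter, if anything slightly upward. For compound 3 the expected value in this assay is 38%, between 25% and 52%, a step of a number 4.9 percentage points higher from compound 2 to compound 3 (within the scatter).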

Compound 3, a percentage reported as inhibition, in the whole organism at one dose (the size of the read-out at that dose, not a potency): 36.3%
Beside the measured number, compound 3's estimate is 1.7 percentage points above it; measured number inside the range.
By their numbers in this assay, from the lowest: compounds 2, 3 and 1 (each within the scatter of the next).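

In this assay, within the data shown here, the first measured pair at this saturated ring carbon shows a number 3.2 percentage points higher from compound 2 to compound 3 (within the scatter) when 4-chlorophenyl takes the place of furan-2-yl. At this position and dose, the two aromatic rings therefore cannot be told apart, although one is five-membered with an oxygen and the other six-membered with a chlorine on it. Nothing at hand offers a reason for this result. Still open, from the compounds shown here alone, is whether an aminomethyl group or a carboxylic acid on this carbon would give a step beyond the scatter. Going by these compounds, whether this change reads the same at other doses also stays open.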